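Adding a third chloro to the dichlorophenyl analogue

The source may report more compounds than this note shows. Statements on the series, on what has been measured and on what is new or still open speak of the compounds shown alone.

Values in a functional assay on DU-145 cells (Homo sapiens) for inhibition, read by trypan blue exclusion, with a stated time of 96 h (a lower number here means a stronger inhibitor of growth, a higher number a weaker inhibitor of growth), for the compounds measured so far

compound 1 `O=C(/C(=C\c1ccc(Br)cc1)SCc1ccc(Cl)cc1)c1ccc(Br)cc1` gives 1000 nM
compound 2 `COc1ccc(/C=C(/SCc2ccc(Cl)cc2)C(=O)c2ccc(Br)cc2)cc1` gives 10000 nM
compound 3 `O=C(/C(=C\c1cccc(Cl)c1Cl)SCc1ccc(Cl)cc1)c1ccc(Br)cc1` gives 10000 nM

Compound 3 stands level with compound 2, and together they hold the highest of the three numbers, well short of compound 1 as a growth inhibitor. The next compound is compound 4 `O=C(/C(=C\c1cc(Cl)cc(Cl)c1Cl)SCc1ccc(Cl)cc1)c1ccc(Br)cc1`, which has chloro in place of hydrogen on an aromatic carbon, taking 2,3-dichlorophenyl to 2,3,5-trichlorophenyl (chloro in place of hydrogen on an aromatic carbon). Going by the values given here, no measured step adds a chloro to this ring, so the evidence is only indirect. Exchanging the aryl group gave a 10-fold higher number from compound 1 to compound 3 (1.00 log units; beyond the scatter), a modest step, and no change at the digits printed from compound 2 to compound 3 (within the scatter), which lies within the scatter. The bromo to methoxy change gave a 10-fold higher number from compound 1 to compound 2 (1.00 log units; beyond the scatter), also modest. Among the compounds with values here, both modest steps start from compound 1, while the only step that starts from a value at the level of compound 3 shows no change. On that basis, no step beyond the scatter is expected in this assay, and no direction is favoured with any confidence. The expected step is a 1.3-fold lower number from compound 3 to compound 4 (0.10 log units; within the scatter) for this single added chloro. The estimate for compound 4 is 8000 nM, with an expected range from 2500 nM to 25000 nM when measured.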

Compound 4, concentration for 50% growth inhibition: 1000 nM
Beside the measured number, compound 4's estimate is 8.0-fold (0.90 log units) above it; measured number below the stated range.
By their numbers in this assay, from the lowest: compounds 1 and 4 (each within the scatter of the next); then compounds 2 and 3 (each within the scatter of the next).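

In this assay, a 10-fold lower number from compound 3 to compound 4 (1.00 log units; beyond the scatter), so a single chloro on this aromatic carbon, meta to a chloro group and a large group and para to another chloro group, moves the value beyond the scatter, something the earlier aryl exchanges could not isolate. The exchange of whole aryl groups now reads a 10-fold lower number from compound 2 to compound 4 (1.00 log units; beyond the scatter) and no change at the digits printed from compound 1 to compound 4 (within the scatter), so the lower value in this set is no longer confined to the 4-bromophenyl group and is shared by 2,3,5-trichlorophenyl. No measurement in hand accounts for the effect of the added chloro.

As far as these compounds go, it remains open whether this position specifically requires a chloro, or whether bromo, methyl, nitrile or an amine on the same carbon would give a similar value in this assay. The compounds shown also leave open whether the added chloro needs the two chloro groups already on the ring, and whether the same step would appear with a group other than 4-bromophenyl on the carbonyl.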